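This account rests on a few compounds, and the source may have more. Where it says the series, first, only, none or still open, it means among the compounds named here.

Of the compounds shown here, three have been tested in a functional assay on cells for agonist activity at Glucose-dependent insulinotropic receptor (Homo sapiens), read by a luciferase reporter, with a stated time of 4 h; a higher number here means a larger maximal response, a lower number a smaller maximal response. Compound 1 `CC(=O)c1cnc(N2CCC(c3coc4c(N5CCc6cc(S(C)(=O)=O)ccc65)ncnc34)CC2)nc1` gives 12%. Compound 2 `CC(C)(C)OC(=O)N1CCC(c2csc3c(Nc4ccc(S(C)(=O)=O)cc4F)ncnc23)CC1` reaches 82%, and compound 3 `CC(C)(C)OC(=O)N1CCC(c2c[nH]c3c(Nc4ccc(S(C)(=O)=O)cc4F)ncnc23)CC1` shows 9%. Among these three numbers, compound 1 stands second highest: its value and that of compound 3 lie within the scatter of each other, so nothing can be said about which is larger, while compound 2 lies well beyond the scatter above compound 1. No pair among these compounds differs in a single place, so no measured step links them.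

Compound 4 `CS(=O)(=O)c1ccc2c(c1)CCN2c1ncnc2c(C3CCN(c4ncc(Cl)cn4)CC3)coc12` is not yet measured. It comes from compound 1 by one change, (chloro in place of acetyl on an aromatic carbon). The acetyl group, with its one hydrogen-bond acceptor, leaves the six-membered aromatic ring with two nitrogens, and a single chlorine takes its place, para to a large group.

Among the compounds with values here, no measured step gives a direct guide to this swap. With the rest of the molecule unchanged, the step from compound 1 to compound 4 is expected to be small, a number 3 percentage points higher from compound 1 to compound 4 (within the scatter), likely within the scatter and without a clear direction. Compound 4 is therefore estimated at 15%, with a range from 3% to 40%.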

Compound 4, largest response reached (Emax), in percent of the reference or control that the assay uses: 117%
Estimate against measurement, compound 4: 102 percentage points below; measured number outside the range, above it.
By their numbers in this assay, from the lowest: compounds 3 and 1 (each within the scatter of the next); then compound 2; then compound 4.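

The substituent at this place on the ring turns out to matter far more than the opening comparison could suggest: in this assay, replacing acetyl with chloro gives a number 105 percentage points higher from compound 1 to compound 4 (beyond the scatter), and compound 4 reaches 117%. Compounds 1, 2 and 3 differ from each other in more than one place, so their spread could not be tied to any single group, whereas this pair ties a large change in maximal response to the swap from 5-acetylpyrimidin-2-yl to 5-chloropyrimidin-2-yl alone. Nothing available here explains why this swap has so large an effect.

With only acetyl and chloro seen at this place, the compounds shown cannot separate the effect of removing acetyl from the effect of adding chloro, and a hydrogen, fluoro, bromo, methyl, methoxy or nitrile there would help to tell these apart. On these data alone, the read-out also describes only the largest response reached, so the concentration that compound 4 needs to produce that response remains open.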